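Swapping 4-bromophenyl for 2-chlorophenyl on the shared core

A few compounds are considered here, and "the series" means these few. Any claim that something is new, unique, unknown or untested is made for them only; others in the source may bear on it.

Measured so far in a functional assay on the whole organism (strain Wistar albino) for inhibition, with Rattus norvegicus as the target, read by paw edema, with stated times of 30 min and 1.5 h, at a dose of 20 mg/kg by the oral route; a higher number here means more inhibition at the dose given (going by the name of the read-out), a lower number less inhibition:
compound 1 `CCCc1nn2c(C(C)c3ccc(CC(C)C)cc3)nnc2s1` gives 24%
compound 2 `CC(C)Cc1ccc(C(C)c2nnc3sc(-c4ccc(Br)cc4)nn23)cc1` gives 69%

Compound 2 stands highest of the two numbers; its nearest neighbour is compound 1, and the step of a number 45 percentage points higher from compound 1 to compound 2 (beyond the scatter) lies beyond the scatter. Among the compounds with values here, that step replaces a propyl by a 4-bromophenyl on the aromatic carbon of the five-membered ring of the shared core, and it is the only step measured.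

Compound 3 `CC(C)Cc1ccc(C(C)c2nnc3sc(-c4ccccc4Cl)nn23)cc1` is the next candidate for this assay. The change from compound 2 is 2-chlorophenyl in place of 4-bromophenyl on an aromatic carbon, at the same place on the five-membered aromatic ring with two nitrogen and one sulfur. Within the data shown here, no measured step compares one six-membered aromatic ring against another at this place, so the only bearing is indirect: the large step from compound 1 to compound 2 shows that an aromatic ring there goes with the higher number, and compound 3 keeps such a ring.

The step of a number 9 percentage points lower from compound 2 to compound 3 (within the scatter) is therefore expected to stay within the scatter. Compound 3 is estimated to give 60%, in the range 40% to 78%.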

Compound 3, a percentage reported as inhibition, in the whole organism at one dose (the size of the read-out at that dose, not a potency): 57%
The estimate for compound 3 lay 3 percentage points above the measured number; measured number inside the range.
By their numbers in this assay, from the lowest: compound 1; then compound 3; then compound 2.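

Swapping 4-bromophenyl for 2-chlorophenyl in this assay gives a number 12 percentage points lower from compound 2 to compound 3 (beyond the scatter) and is the first comparison of two aryl groups on this aromatic carbon, so the read-out at this dose depends on more than the presence of a six-membered aromatic ring there. The aromatic ring still holds up against the alkyl chain with the new group, since a number 33 percentage points higher from compound 1 to compound 3 (beyond the scatter) points the same way as the step from propyl to 4-bromophenyl, and none of the three compounds goes against this. The groups that leave and enter match in the counts of heavy atoms, donors and acceptors, and no measurement on these compounds accounts for the difference between them.

This swap changes the halogen and its place on the phenyl ring together, so the compounds shown do not separate the two contributions; 4-chlorophenyl, 2-bromophenyl and unsubstituted phenyl would do so. Also open, as far as these compounds go, is how this position responds to a ring carrying an amine or a carboxylic acid, and whether the order holds at other doses.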